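This account rests on a few compounds, and the source may have more. Where it says the series, first, only, none or still open, it means among the compounds named here.

Working notes on the series, read in a functional assay on AGS cells (Homo sapiens) for inhibition, read by reporter gene assay; a higher number here means a weaker inhibitor, a lower number a stronger inhibitor. Compound 1 `O=C(COc1ccccc1)Nc1cccc(C(=O)O)c1` is reported only as a limit, > 30000 nM. Compound 3 `CC(=O)c1ccc(OCC(=O)Nc2cccc(C(=O)O)c2)cc1` is also reported only as a limit, > 30000 nM. Going by the values given here, compound 2 `CC(C)(C)c1ccc(OCC(=O)Nc2cccc(C(=O)O)c2)cc1` gives 9500 nM, the only true number so far. Compound 4 `O=C(COc1ccc(I)cc1)Nc1cccc(C(=O)O)c1` carries iodo in place of tert-butyl on an aromatic carbon, para to a large group: iodo in place of tert-butyl on an aromatic carbon. Among the compounds with values here, two measured steps bear on this change. Tert-butyl in place of hydrogen gave an at least 3.1-fold lower number from compound 1 to compound 2 (0.49 log units; beyond the scatter), and acetyl in place of tert-butyl gave an at least 3.1-fold higher number from compound 2 to compound 3 (0.49 log units; beyond the scatter). Both are bounded by limits, and neither involves iodo. Losing tert-butyl therefore leads to an expected modest rise in this assay, estimated as a 1.6-fold higher number from compound 2 to compound 4 (0.20 log units; within the scatter). The estimate for compound 4 is 15000 nM, with an expected range of 5000 nM to 30000 nM.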

Compound 4, half-maximal inhibitory concentration: 3500 nM
Beside the measured number, compound 4's estimate is 4.3-fold (0.63 log units) above it, outside the stated range (below it).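

At this position, iodo in place of tert-butyl gives a 2.7-fold lower number from compound 2 to compound 4 (0.43 log units; beyond the scatter) in this assay, so one iodine atom outdoes four carbons here, and compound 4 has the lowest number of the four. Iodo in place of hydrogen gives an at least 8.5-fold lower number from compound 1 to compound 4 (0.93 log units; beyond the scatter), and iodo in place of acetyl gives an at least 8.5-fold lower number from compound 3 to compound 4 (0.93 log units; beyond the scatter). Both of these steps are bounded rather than exact, as each starts from a limit: the limit of > 30000 nM in this assay, at which 2 of the 4 values shown sit.

As far as these compounds go, whether chloro, bromo or trifluoromethyl at this position would track iodo or tert-butyl stays open.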